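The source may report more compounds than this note shows. Statements on the series, on what has been measured and on what is new or still open speak of the compounds shown alone.

The measured compounds:
compound 1 `N#Cc1ncc(C(=O)Nc2cc(C(F)(F)F)cc(C(F)(F)F)c2)c(C(F)(F)F)n1`;
compound 2 `Cc1nc(Cl)ncc1C(=O)Nc1cc(C(F)(F)F)cc(C(F)(F)F)c1`;
compound 3 `CCc1nc(Cl)ncc1C(=O)Nc1cc(C(F)(F)F)cc(C(F)(F)F)c1`.

In an assay on Jurkat cells for activation of nuclear factor NF-kappa-B complex (Homo sapiens) (on this read-out higher numbers stand for weaker inhibition and lower numbers for stronger inhibition), compound 2 gives 50 nM. Compound 3 gives 400 nM. For compound 1 the result is only a limit of the assay, > 10000 nM, so no number is known for it; this is the case noted as the limit of > 10000 nM in this assay, at which 1 of the 3 values shown sits. Of the two numbers that exist, compound 2 stands lowest, and its nearest neighbour is compound 3, reached by an 8.0-fold higher number from compound 2 to compound 3 (0.90 log units; beyond the scatter).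

Compound 4 `O=C(Nc1cc(C(F)(F)F)cc(C(F)(F)F)c1)c1ccc(Cl)nn1` has not yet been measured. It differs from compound 2 in 6-chloropyridazin-3-yl in place of 2-chloro-4-methylpyrimidin-5-yl on a carbonyl carbon. For the measured compounds named here, the only measured step concerns the methyl on a saturated chain carbon, where growing it to ethyl was a modest loss. Going by the values given here, no measured pair exchanges the ring bound to the carbonyl carbon, so that step bears on compound 4 only indirectly: compound 4 both changes the ring and no longer carries the methyl of compound 2. The account therefore expects a weaker result than compound 2, of uncertain size, with a broad range rather than a confident prediction.

Compound 4 is estimated at 500 nM, with a range from 50 nM to 5000 nM. That estimate corresponds to an expected step of a 10-fold higher number from compound 2 to compound 4 (1.00 log units; beyond the scatter).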

Compound 4, half-maximal inhibitory concentration: 1700 nM
For compound 4 the middle estimate is 3.4-fold (0.53 log units) below the measured one; the range from low to high includes it.
By their numbers in this assay, from the lowest: compound 2; then compound 3; then compound 4. At a limit, above all of these: compound 1.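

In this assay, the ring on the carbonyl carbon proves to be a sensitive place: exchanging it gives a 34-fold higher number from compound 2 to compound 4 (1.53 log units; beyond the scatter), a large step, whereas growing the methyl to ethyl gave the modest 8.0-fold higher number from compound 2 to compound 3 (0.90 log units; beyond the scatter). The entering 6-chloropyridazin-3-yl and the leaving 2-chloro-4-methylpyrimidin-5-yl are both six-membered aromatic rings with the same counts of hetero atoms, hydrogen-bond donors and acceptors and each carries a chlorine, so these shared counts alone do not preserve the result. Nothing measured here explains the loss.

The exchange alters the placing of the ring's hetero atoms and removes the methyl in one step, so the compounds shown cannot divide the loss between the two; the 2-chloro-4-methylpyrimidin-5-yl ring without its methyl, or the 6-chloropyridazin-3-yl ring with a methyl added, would separate them. Also open, from the compounds shown here alone, is whether the chlorine of either ring can give way to an amine or a methoxy group, and how either change would read in this assay.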